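The source may hold more compounds than are shown below. What is called first, only, known or untested is meant among the compounds shown, and "the series" means these compounds.

Three close relatives of one shared core have been tested in an assay on isolated protein for inhibition of leukotriene B4 receptor 1 (Homo sapiens), tested at 10 uM; a higher number here means more inhibition at the concentration tested (going by the name of the read-out), a lower number less inhibition. Compound 1 `CCCCc1cc(C(C)=O)c(O)cc1OCCCCC#N` gives 41% in this assay. Compound 2 `CCCCCc1cc(C(C)=O)c(O)cc1OCCCCC#N` gives 31% in this assay. Among the compounds with values here, the single change between these two, (methyl in place of hydrogen on a saturated chain carbon, four bonds along the chain from an aromatic carbon), made a step of a number 10 percentage points lower from compound 1 to compound 2 (within the scatter). Compound 3 `C=CCc1cc(C(C)=O)c(O)cc1OCCCC` gives 32% in this assay; how its core differs from the core of compound 1 is not broken down here. Compound 4 `C=CCc1cc(C(C)=O)c(O)cc1OCCCCC` has not yet been measured in this assay. It differs from compound 3 by methyl in place of hydrogen on a saturated chain carbon, four bonds along the chain from an oxygen on an aromatic ring. Within the data shown here, this is the same kind of change as the one made from compound 1 to compound 2, but not the same: there the methyl entered four bonds along the chain from an aromatic carbon, here it enters four bonds along the chain from an oxygen on an aromatic ring. The earlier step was a number 10 percentage points lower from compound 1 to compound 2 (within the scatter). Resting on that single example, compound 4 is expected to show a step of a number 4 percentage points lower from compound 3 to compound 4 (within the scatter). Compound 4 is therefore estimated to give 28% in this assay, with a likely range from 12% to 44%.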

Compound 4, a percentage reported as inhibition, at one concentration (the size of the read-out at that concentration, not a potency): 60%
Estimate against measurement, compound 4: 32 percentage points below; measured number outside the range, above it.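

In this assay, placing a methyl on a saturated chain carbon, four bonds along the chain from an oxygen on an aromatic ring, gave a number 28 percentage points higher from compound 3 to compound 4 (beyond the scatter). Set beside the earlier step, this shows that a single added methyl did not have the same outcome on these two cores, so the result from one could not simply be carried over to the other: the same change on two cores in this assay, a number 10 percentage points lower (within the scatter) from compound 1 to compound 2 and a number 28 percentage points higher (beyond the scatter) from compound 3 to compound 4, 38 percentage points apart, beyond the scatter of two such steps

It does not show why the two steps part: the methyl enters at a different place in each, the cores differ as well, and two examples give no rule for a further core. Left open is whether a longer chain in place of the one carrying the new methyl would move the number further in the same direction, or how a carboxylic acid at the end of that chain would read. Each number here is also inhibition at a single concentration, so none of them gives a potency.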